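A few compounds are considered here, and "the series" means these few. Any claim that something is new, unique, unknown or untested is made for them only; others in the source may bear on it.

Measured so far in a functional assay on PC-3 cells (Homo sapiens) for inhibition, read by MTT assay, with a stated time of 48 h; a higher number here means a weaker inhibitor, a lower number a stronger inhibitor:
Compound 1, `Cn1c(/C=C2\SC(=O)N(CC(=O)Nc3cc(C(C)(C)C)on3)C2=O)nc2ccccc21`: > 50000 nM, which is a limit of the assay and not a number.
Compound 2, `CCn1c(/C=C2\SC(=O)N(CC(=O)N3CCc4cc(OC)c(OC)cc4C3)C2=O)nc2ccccc21`: 33500 nM.
Compound 3, `COc1cc2c(cc1OC)CN(C(=O)CN1C(=O)S/C(=C\c3nc4ccccc4n3C(C)C)C1=O)CC2`: > 50000 nM, again a limit and not a number.

Compound 3 thus sits at the ceiling of this assay, a position shared by most of the values here (the limit of > 50000 nM in this assay, at which 2 of the 3 values shown sit). Among the compounds with values here, only compound 2 yields a number, and the single measured change, an at least 1.4-fold higher number from compound 2 to compound 3 (0.17 log units; that floor lies within the scatter), has a floor that stays inside the scatter, so it shows no firm direction.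

Compound 4, `COc1cc2c(cc1OC)CN(C(=O)CN1C(=O)S/C(=C\c3nc4ccccc4n3C)C1=O)CC2`, differs from compound 3 by methyl in place of isopropyl on an aromatic nitrogen. This touches the same spot as the measured step but moves the other way, toward a smaller group. Compound 1 carries a methyl there too, yet with a different amide, so it cannot settle the question on its own. With one number and one step inside the scatter, no shift beyond the scatter is expected in this assay; a value near the limit, or the limit itself, seems most plausible.

Compound 4 is therefore expected at 45000 nM, between 20000 nM and 100000 nM, with a fair chance that only a limit is reported. That expected step is an at least 1.1-fold lower number from compound 3 to compound 4 (0.04 log units; that floor lies within the scatter).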

Compound 4, half-maximal inhibitory concentration: 41100 nM
Beside the measured number, compound 4's estimate is 1.1-fold (0.04 log units) above it; low and high end bracket the measured number.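

In this assay, within the data shown here, compound 4 gives this position on the aromatic nitrogen a second true number, and that number cannot be told apart from the one for compound 2: a 1.2-fold higher number from compound 2 to compound 4 (0.09 log units; within the scatter). Trading isopropyl for methyl, the change tested here, gives an at least 1.2-fold lower number from compound 3 to compound 4 (0.08 log units; that floor lies within the scatter), so this swap shows no firm direction either, and the small carbon groups on this nitrogen do not yet separate from one another in this assay. That step can be read only as a floor because compound 3 carries a limit and not a number: the limit of > 50000 nM in this assay, at which 2 of the 4 values shown sit.

The compounds shown leave open whether any group on this nitrogen can move the number beyond the scatter, since they span only short saturated carbon groups there. Going by these compounds, how a benzyl group, or a longer chain ending in an amine, would read at this position remains unknown, as does the result for a plain hydrogen on that nitrogen.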